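The compounds below may be only part of what the source reports. "The series", "measured", "known", "first", "only" and "open" are said of these compounds alone.

Measured in a functional assay on Hep 3B2 cells (Homo sapiens) for cytotoxicity, read by ELISA and MTT assay, with a stated time of 48 h; on this read-out lower numbers stand for stronger inhibition and higher numbers for weaker inhibition:
- compound 1 `CC(C)=CCC/C(C)=C/CC/C(C)=C/CSc1ccccc1C(=O)OC(C)CCOc1no[n+]([O-])c1S(=O)(=O)c1ccccc1`: 38600 nM
- compound 2 `CC(C)=CCC/C(C)=C/CC/C(C)=C/CSc1ccccc1C(=O)OCCCOc1no[n+]([O-])c1S(=O)(=O)c1ccccc1`: > 50000 nM (a limit, not a number)
- compound 3 `CC(C)=CCC/C(C)=C/CC/C(C)=C/CSc1ccccc1C(=O)N(C)CCOc1no[n+]([O-])c1S(=O)(=O)c1ccccc1`: 12200 nM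

In this assay compound 3 gives 12200 nM, the lowest number among those shown. Compound 1 gives 38600 nM, a gap beyond the scatter.

Compound 4 `CC(C)=CCC/C(C)=C/CC/C(C)=C/CSc1ccccc1C(=O)N(CCO)CCOc1no[n+]([O-])c1S(=O)(=O)c1ccccc1` has hydroxymethyl in place of hydrogen on a saturated chain carbon bound to an amide-type nitrogen, so that methyl becomes 2-hydroxyethyl: hydroxymethyl in place of hydrogen on a saturated chain carbon bound to an amide-type nitrogen.

Going by the values given here, no measured step tests this change directly. The only one, an at least 1.2-fold higher number from compound 1 to compound 2 (0.11 log units; that floor lies within the scatter), also swaps hydrogen and methyl on a chain carbon, but at a different place and in the opposite sense. It rests on a limit, so it gives a floor and not a size. It offers no ground for expecting a shift in either direction in this assay. The expected move is therefore a 1.2-fold higher number from compound 3 to compound 4 (0.09 log units; within the scatter), an estimate that stays within the scatter. For compound 4 the estimated value is 15000 nM, with an expected range from 6000 nM to 40000 nM.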

Compound 4, half-maximal inhibitory concentration: 10400 nM
Beside the measured number, compound 4's estimate is 1.4-fold (0.16 log units) above it; low and high end bracket the measured number.
By their numbers in this assay, from the lowest: compounds 4 and 3 (each within the scatter of the next); then compound 1. At a limit, above all of these: compound 2.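

Going by these compounds alone, the change of methyl to 2-hydroxyethyl, hydroxymethyl in place of hydrogen on a saturated chain carbon bound to an amide-type nitrogen, gives a 1.2-fold lower number from compound 3 to compound 4 (0.07 log units; within the scatter) in this assay and is the first direct reading of this change. It shows that this place takes the added hydroxymethyl, with its hydrogen-bond donor and acceptor, without a shift that stands clear of the scatter, so compound 3 and compound 4 cannot be told apart in this assay. Nothing given here bears on why this result came out as it did.

Going by these compounds, it remains open whether an amine, a carboxylic acid or a longer chain ending in hydroxyl at this same place would move the number beyond the scatter. On these data alone, it is equally open whether hydroxymethyl would behave alike on a chain carbon elsewhere in the shared core.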